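Morpholine Amide in Place of Hydroxymethyl on the Shared Core

A few compounds are considered here, and "the series" means these few. Any claim that something is new, unique, unknown or untested is made for them only; others in the source may bear on it.

Compound 1 `CC#C[C@@H](CC(=O)O)c1ccc(OC[C@H]2COc3ccc(Br)cc3O2)cc1`: 69% in a functional assay on HEK293 cells for agonist activity at Free fatty acid receptor 1 (Homo sapiens), read by fluorescence and calcium flux, with a stated time of 10 min; on this read-out lower numbers stand for smaller maximal responses and higher numbers for larger maximal responses
Compound 2 `CC#C[C@@H](CC(=O)O)c1ccc(OC[C@H]2COc3ccc(OC(F)(F)F)cc3O2)cc1`: 73% in this assay
Compound 3 `CC#C[C@@H](CC(=O)O)c1ccc(OC[C@H]2COc3ccc(CO)cc3O2)cc1`: 42% in this assay

Compound 3 stands lowest of the three numbers in this assay: a number 27 percentage points lower from compound 1 to compound 3 (beyond the scatter) and a number 31 percentage points lower from compound 2 to compound 3 (beyond the scatter), both beyond the scatter, whereas the remaining pair lies within the scatter of each other: a number 4 percentage points higher from compound 1 to compound 2 (within the scatter). Compound 4 `CC#C[C@@H](CC(=O)O)c1ccc(OC[C@H]2COc3ccc(C(=O)N4CCOCC4)cc3O2)cc1` differs from compound 3 at a single aromatic carbon: (morpholin-4-yl)carbonyl in place of hydroxymethyl on an aromatic carbon. For the measured compounds named here, none of the measured steps exchanges hydroxymethyl for a carbonyl-bearing group, so no step bears directly on this change; the two steps into compound 3 show only that hydroxymethyl gives the smaller maximal response against bromo and against trifluoromethoxy. The direction for compound 4 is therefore open, and the expected step is a number 13 percentage points higher from compound 3 to compound 4 (beyond the scatter) in this assay, an estimate that may not exceed the scatter. Compound 4 is estimated to give 55% in this assay, with a range from 35% to 75%.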

Compound 4, largest response reached (Emax), in percent of the reference or control that the assay uses: 33%
Compound 4: middle estimate off by 22 percentage points, on the high side; measured number below the stated range.
By their numbers in this assay, from the lowest: compounds 4 and 3 (each within the scatter of the next); then compounds 1 and 2 (each within the scatter of the next).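

In this assay, replacing hydroxymethyl with (morpholin-4-yl)carbonyl gives a number 9 percentage points lower from compound 3 to compound 4 (within the scatter), so the maximal response does not separate these two groups at this aromatic carbon. The amide stands well apart from the other two groups, with a number 40 percentage points lower from compound 2 to compound 4 (beyond the scatter) and a number 36 percentage points lower from compound 1 to compound 4 (beyond the scatter), so among these compounds the lower response appears both with a hydrogen-bond donor in the group, as in compound 3, and without one, as in compound 4. Nothing given here explains why these groups separate in this way. The compounds shown leave open whether a nitrile or a plain methyl on this aromatic carbon would stand with bromo and trifluoromethoxy or with hydroxymethyl and the morpholine amide. Going by these compounds, it is equally open where a carboxylic acid or an open-chain dimethyl amide would fall.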